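Trading an aryl ketone for a small amide on the chain

The source may report more compounds than this note shows. Statements on the series, on what has been measured and on what is new or still open speak of the compounds shown alone.

Compound 2 `CC(C)C[C@H](N)c1cc(C(F)(F)F)ccc1N1CCN(C(=O)CC(C)C(=O)c2ccc(Cl)cc2)CC1` is the weaker of the two measured compounds in an assay on HEK293 cells for displacement of a labelled ligand from Melanocortin receptor 4 (Homo sapiens) (a lower number here means a stronger inhibitor, a higher number a weaker inhibitor), giving 1100 nM, whereas compound 1 `CC(C)C[C@H](N)c1cc(Cl)ccc1N1CCN(C(=O)C(C)Cc2ccc(Cl)cc2)CC1` gives 67 nM. Compound 3 `CC(C)C[C@H](N)c1cc(C(F)(F)F)ccc1N1CCN(C(=O)CCC(=O)N(C)C)CC1` keeps the core of compound 2 but changes the chain on the amide carbonyl: (dimethylcarbamoyl)methyl in place of 1-((4-chlorophenyl)carbonyl)ethyl on a saturated chain carbon bound to a carbonyl carbon. The leaving group is larger and carries an aromatic ring; the entering group is small and has none. Among the compounds with values here, with no measured step of this kind to lean on, a further loss of binding is expected, from compound 2 to compound 3 a 3.2-fold higher number from compound 2 to compound 3 (0.50 log units; beyond the scatter). Compound 3 is estimated at 3500 nM, within 900 nM to 14000 nM.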

Compound 3, inhibition constant: > 10000 nM
Compound 3: a limit, no number (the forecaster's own chance of this, stated with the estimate: 25%); middle value at least 2.8-fold (0.45 log units) from the limit.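

Within the data shown here, this is the first step with the core held fixed, so it shows that binding depends on what this chain carries: (dimethylcarbamoyl)methyl in place of 1-((4-chlorophenyl)carbonyl)ethyl gives an at least 9.0-fold higher number from compound 2 to compound 3 (0.95 log units; beyond the scatter). In this assay, compound 3 gives > 10000 nM, a limit of the assay and not a number. The true size of the loss therefore stays unknown: the limit of > 10000 nM in this assay, at which 1 of the 3 values shown sits.

This single change removes the aromatic ring and alters the rest of the chain together, so the part that matters cannot be singled out. Open too, on these data alone, is how a plain phenyl ketone, or an amine at the chain end, would read.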